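Compound 1 to compound 3: swapping the aryl end group

The source may report more compounds than this note shows. Statements on the series, on what has been measured and on what is new or still open speak of the compounds shown alone.

Measured in a functional assay on Gurav cells (Homo sapiens) for inhibition, read by sulforhodamine B assay; a higher number here means a weaker inhibitor of growth, a lower number a stronger inhibitor of growth
- compound 1 `COc1ccc(-c2ccc(-c3ccc(-c4nc5cc(C)ccc5[nH]4)cc3)cc2)cc1OC` gives 1310 nM
- compound 2 `COc1cc(-c2ccc(-c3ccc(-c4nc5cc(C)ccc5[nH]4)cc3)cc2)cc(OC)c1OC` gives 170 nM

Not yet measured: compound 3 `Cc1ccc2[nH]c(-c3ccc(-c4ccc(-c5ccc(O)cc5)cc4)cc3)nc2c1`

Of the two measured numbers, the higher belongs to compound 1, at 1310 nM. The change under review is 4-hydroxyphenyl in place of 3,4-dimethoxyphenyl on an aromatic carbon, which sits para to a large group. For the measured compounds named here, one measured step bears on it: a 7.7-fold lower number from compound 1 to compound 2 (0.89 log units; beyond the scatter), with methoxy in place of hydrogen on an aromatic carbon. That step adds a methoxy, whereas compound 3 loses both methoxy groups of compound 1 and gains a hydroxy. Going by the values given here, no measured compound carries a hydroxy, so the step gives only weak guidance and no firm direction. No shift beyond the scatter is therefore expected in this assay. The expected step is a 1.2-fold lower number from compound 1 to compound 3 (0.08 log units; within the scatter). Compound 3 is estimated at 1100 nM, with an expected range of 250 nM to 4500 nM.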

Compound 3, concentration for 50% growth inhibition: 11300 nM
Compound 3: the middle estimate sits 10-fold (1.01 log units) below what was measured; the measured number lies above the stated range.
By their numbers in this assay, from the lowest: compound 2; then compound 1; then compound 3.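

Notes on the aryl end group: in this assay this group, on an aromatic carbon para to a large group, can also push the number up, since 4-hydroxyphenyl in place of 3,4-dimethoxyphenyl gives an 8.6-fold higher number from compound 1 to compound 3 (0.94 log units; beyond the scatter) beyond what the earlier pair showed. The earlier pair showed only the favourable direction, with a 7.7-fold lower number from compound 1 to compound 2 (0.89 log units; beyond the scatter) on adding a methoxy, so the end group now moves the number both ways across these three compounds. No supporting data bear on why the hydroxy swap raises the number.

On these data alone, this swap removes both methoxy groups and adds a hydroxy in one step, so the share of each change stays open. As far as these compounds go, a 4-methoxyphenyl end group would separate them, and an amine or a carboxylic acid at the same carbon remains open as well.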